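A few compounds are considered here, and "the series" means these few. Any claim that something is new, unique, unknown or untested is made for them only; others in the source may bear on it.

Compound 1 `C[C@@H](C(=O)N[C@H](C#N)CC(N)=O)N(Cc1ccc(-c2cc(F)cc(F)c2)cc1)S(C)(=O)=O` and compound 2 `C[C@H](C(=O)N[C@H](C#N)CC(N)=O)N(Cc1ccc(-c2cc(F)cc(F)c2)cc1)S(C)(=O)=O` contain the same atoms and bonds. In an assay on isolated protein for inhibition of legumain (Homo sapiens), with stated times of 2 min and 60 min (a higher number here means a weaker inhibitor, a lower number a stronger inhibitor), compound 1 gives 1360 nM, whereas compound 2 gives 9250 nM, the highest of the two numbers seen so far; the step of a 6.8-fold higher number from compound 1 to compound 2 (0.83 log units; beyond the scatter) rests only on (the fact that compounds 1 and 2 differ only in the configuration as drawn). Compound 3 `CC(C)Oc1cccc(-c2ccc(CN([C@H](C)C(=O)N[C@H](C#N)CC(N)=O)S(C)(=O)=O)cc2)c1` carries 3-isopropoxyphenyl in place of 3,5-difluorophenyl on an aromatic carbon. Going by the values given here, no measured step touches this outer ring, so nothing here points in either direction, and a 1.2-fold lower number from compound 2 to compound 3 (0.06 log units; within the scatter) is expected to stay close to where compound 2 already stands. Compound 3 is therefore estimated at 8000 nM, within a range from 2000 nM to 30000 nM.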

Compound 3, half-maximal inhibitory concentration: 5050 nM
Estimate against measurement, compound 3: 1.6-fold (0.20 log units) above; the range from low to high includes it.
By their numbers in this assay, from the lowest: compound 1; then compounds 3 and 2 (each within the scatter of the next).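

In this assay the change of outer ring gives a 1.8-fold lower number from compound 2 to compound 3 (0.26 log units; within the scatter) and so shows that, at this position on an aromatic carbon, 3-isopropoxyphenyl and 3,5-difluorophenyl cannot be told apart. This holds even though the entering group has more heavy atoms and a hydrogen-bond acceptor that the leaving group lacks. Nothing measured here explains this result. From the compounds shown here alone, whether the same holds in the configuration of compound 1 remains open, as does how an amine or a carboxylic acid on this outer ring would read.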